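The source may report more compounds than this note shows. Statements on the series, on what has been measured and on what is new or still open speak of the compounds shown alone.

Compound 3 `O=C(COc1cccc2ccccc12)N/N=C/c1ccc([N+](=O)[O-])cc1` carries a nitro group, and compound 1 `O=C(COc1cccc2ccccc12)N/N=C/c1ccc(Cl)cc1` is its counterpart with chloro in that position, a change summed up as chloro in place of nitro on an aromatic carbon. In an ADME assay on HEL cells (Homo sapiens) for cytotoxicity (a higher number here means that more compound is tolerated, a lower number that less compound is tolerated), compound 3 gives 20 ug/mL, while compound 1 gives 100 ug/mL, so the swap produced a 5.0-fold higher number from compound 3 to compound 1 (0.70 log units; beyond the scatter). Compound 2 `C/C(=N\NC(=O)COc1cccc2ccccc12)c1ccc([N+](=O)[O-])cc1` keeps the nitro group but differs from compound 3 in its core; the difference between the two cores is not broken down here. In this assay compound 2 gives 100 ug/mL, level with compound 1 at the digits recorded and together with it the highest of the three numbers. Compound 4 `C/C(=N\NC(=O)COc1cccc2ccccc12)c1ccc(Cl)cc1` is the chloro counterpart of compound 2, and the change between them, (chloro in place of nitro on an aromatic carbon), is the same one already seen between compound 3 and compound 1, made at the same place. For compound 4 an upward step in this assay is expected, roughly no change at the digits printed from compound 2 to compound 4 (within the scatter), because a 5.0-fold higher number from compound 3 to compound 1 (0.70 log units; beyond the scatter) was the outcome of the identical change. That expectation is tempered by compound 2 already standing at the top of the three values, so the highest concentration such a cell assay is run at may cap what can be read. Compound 4 is therefore estimated at 100 ug/mL, with a likely range from 40 ug/mL to 250 ug/mL.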

Compound 4, minimum cytotoxic concentration in the HEL assay: >= 4 ug/mL
Compound 4: a limit, no number; the forecaster's own chance of this, stated with the estimate: 40%; the middle value lies beyond the limit too.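

Among these compounds, in the HEL assay compound 4 gives >= 4 ug/mL, which is a limit and not a number, so no step from compound 2 to compound 4 can be read. In a physicochemical assay for lipophilicity, measured as octanol-water partition (a lower number here means a more polar compound, a higher number a more lipophilic compound), compound 2 gives 3.37 and compound 4 gives 4.17. The compounds shown leave open whether, in the HEL assay, chloro in place of nitro moves the number on the core of compound 2 as it does from compound 3 to compound 1.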